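A ring nitrogen enters where a methyl once stood

The source may hold more compounds than are shown below. What is called first, only, known or untested is meant among the compounds shown, and "the series" means these compounds.

Of the compounds shown here, three have so far been tested in an ADME assay on HCT-116 cells (Homo sapiens) for cytotoxicity, read by MTT assay; a higher number here means that more compound is tolerated, a lower number that less compound is tolerated. Compound 1 `Cc1nc(-c2cccnc2)sc1-c1nnc(-c2ccc(Cl)cc2)o1` gives > 100 ug/mL, which is a limit of the assay rather than a number. Compound 2 `Cc1cccc(-c2nnc(-c3sc(-c4cccnc4)nc3C)o2)c1` gives > 100 ug/mL, again a limit. Compound 3 `Cc1ccc(-c2nnc(-c3sc(-c4cccnc4)nc3C)o2)cc1` gives > 100 ug/mL, also a limit. Because all three sit at the limit of > 100 ug/mL in this assay, at which 3 of the 3 values shown sit, the steps between them cannot be sized: a step that the two limits leave unreadable from compound 1 to compound 2, a step that the two limits leave unreadable from compound 1 to compound 3 and a step that the two limits leave unreadable from compound 2 to compound 3 all remain unreadable. Compound 3 therefore stands at the limit, alongside the two other values, with nothing to separate it from them.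

Compound 4 `Cc1nc(-c2cccnc2)sc1-c1nnc(-c2ccncc2)o1` has not yet been measured. It differs from compound 3 in one place: pyridin-4-yl in place of 4-methylphenyl on an aromatic carbon. The three measured steps each exchanged the group on an aromatic carbon of the shared core, and none gave a readable size; they bear on this step only in showing that such an exchange has never brought the value down from the limit. The expected size of the step is therefore none beyond the scatter, and a number no higher from compound 3 to compound 4 (the limit leaves the size open) is the expectation written as a number. Compound 4 is estimated at 100 ug/mL, within a range from 50 ug/mL to 200 ug/mL.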

Compound 4, half-maximal cytotoxic concentration: > 100 ug/mL
Compound 4: no number, only a limit; the forecaster's own chance of this, stated with the estimate: 80%; the middle value sits exactly at the limit.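

In this assay compound 4 gives > 100 ug/mL which is a limit and not a number. Among these compounds, no step from compound 1, compound 2 or compound 3 to compound 4 can be read, since all four compounds sit at the same limit: the limit of > 100 ug/mL in this assay, at which 4 of the 4 values shown sit.

The compounds shown leave open how much of any of them cells tolerate, and whether any group in this place would lower that amount.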